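A few compounds are considered here, and "the series" means these few. Any claim that something is new, unique, unknown or untested is made for them only; others in the source may bear on it.

Working notes on the series: in a physicochemical assay for solubility (on this read-out lower numbers stand for lower solubility and higher numbers for higher solubility), compound 1 `O=C(O)c1ccc(C(=O)/C(=C\c2cc([N+](=O)[O-])ccc2F)SCc2ccc(Br)cc2)cc1` has no numerical result. Compound 1 gives < 1000 ug/mL, which is a limit. Compound 2 `O=C(O)c1ccc(C(=O)/C(=C\c2ccc(F)c([N+](=O)[O-])c2)SCc2ccc(F)cc2)cc1` gives < 1000 ug/mL, also a limit. All results so far therefore stand at the limit of < 1000 ug/mL in this assay, at which 2 of the 2 values shown sit. Compound 3 `O=C(O)c1ccc(C(=O)/C(=C\c2ccc(Br)c([N+](=O)[O-])c2)SCc2ccc(Br)cc2)cc1` carries 4-bromo-3-nitrophenyl in place of 2-fluoro-5-nitrophenyl on a double-bonded chain carbon bound to a double-bonded chain carbon. Going by the values given here, no measured step covers this change, so a step that the limit leaves unreadable from compound 1 to compound 3 is expected to stay within the scatter in this assay, with no direction expected. The estimate for compound 3 is 500 ug/mL, with an expected range of 150 ug/mL to 1000 ug/mL.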

Compound 3, solubility: < 1000 ug/mL
Compound 3 gave a limit, no number; the forecaster's own chance of this, stated with the estimate: 85%; the middle value is on the limit's open side.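

In this assay no step can be read from compound 1 to compound 3, both results being limits. Still open, from the compounds shown here alone, is how far each compound lies from its limit in this assay and whether 2-fluoro-5-nitrophenyl and 4-bromo-3-nitrophenyl differ at all.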